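This account rests on a few compounds, and the source may have more. Where it says the series, first, only, none or still open, it means among the compounds named here.

In an ADME assay on BE(2)-C cells (Homo sapiens) for cytotoxicity, read by MTT assay, with a stated time of 20 h (on this read-out lower numbers stand for higher toxicity in this test and higher numbers for lower toxicity in this test), three compounds sharing one core have been measured so far. Compound 3 `CN(Cc1ccccc1)C(=O)C1CCN(C(=O)c2cc3ccccc3n2Cc2ccc([N+](=O)[O-])cc2)CC1` gives > 100000 nM, which is a limit of the assay and not a number. That is the limit of > 100000 nM in this assay, at which 2 of the 3 values shown sit. Compound 1 `Cn1ccc(CNC(=O)C2CCN(C(=O)c3cc4ccccc4n3Cc3ccc(Cl)cc3)CC2)n1` also gives only a limit, > 100000 nM. Compound 2 `CN(Cc1ccccc1)C(=O)C1CCN(C(=O)c2cc3ccccc3n2Cc2ccc(Cl)cc2)CC1` gives a number, 87000 nM.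

Compound 4 `CN(Cc1ccccc1)C(=O)C1CCN(C(=O)c2cc3ccccc3n2Cc2ccc(C#N)cc2)CC1` differs from compound 3 in one place: cyano in place of nitro on an aromatic carbon. The cyano group takes the place of nitro on an aromatic carbon, para to a large group. The measured step closest to this one swaps the group at that same place, chloro for nitro, and reads an at least 1.1-fold higher number from compound 2 to compound 3 (0.06 log units; that floor lies within the scatter). The other measured step, an at least 1.1-fold lower number from compound 1 to compound 2 (0.06 log units; that floor lies within the scatter), concerns a different part of the molecule and bears on the change less directly. Neither step shows a size beyond the scatter, so no shift beyond the scatter is expected in this assay, in either direction. The expected step is a number no higher from compound 3 to compound 4 (the limit leaves the size open). The estimate for compound 4 is 100000 nM, with an expected range from 50000 nM to 200000 nM.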

Compound 4, half-maximal cytotoxic concentration: > 100000 nM
Compound 4 ended at the assay's limit; the forecaster's own chance of this, stated with the estimate: 65%; the middle value sits exactly at the limit.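

On the aromatic carbon para to a large group, cyano is a second group besides nitro that leaves the read-out at the limit, and the change from chloro reads an at least 1.1-fold higher number from compound 2 to compound 4 (0.06 log units; that floor lies within the scatter). The step between nitro and cyano cannot be read: both of its ends are limits. Cyano thus adds one more compound to those stopped at the top of the range, so this position has still shown no shift beyond the scatter: the limit of > 100000 nM in this assay, at which 3 of the 4 values shown sit.

The compounds shown leave open whether any group on this aromatic carbon, such as an amine or a carboxylic acid, would bring the number in this assay down by more than the scatter. They also leave open how far above the limit nitro and cyano lie, and whether they differ at all.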